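A few compounds are considered here, and "the series" means these few. Any claim that something is new, unique, unknown or untested is made for them only; others in the source may bear on it.

The set consists of two measured compounds and one that is still to be tested. Compound 1 `COC(=O)c1ccc(NC(=O)CSc2nncnc2-c2ccccc2Cl)c(Br)c1` was examined in an ADME assay on MT4 cells (Homo sapiens) for cytotoxicity, read by MTT assay (on this read-out lower numbers stand for higher toxicity in this test and higher numbers for lower toxicity in this test), and gave 59000 nM. Compound 2 `O=C(CSc1nncnc1-c1ccccc1Cl)Nc1ccc(Cl)cc1Cl` was examined in the same way, and in this assay compound 2 gave 51000 nM. For the measured compounds named here, compound 2 thus sits at one end of the two numbers known so far, with compound 1 a short distance away; the gap between the two falls within the usual scatter of this test, so the two results cannot be told apart.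

Compound 3 `O=C(CSc1nncnc1-c1ccccc1Cl)Nc1ccccc1[N+](=O)[O-]` has not yet been measured. Compared with compound 2 it differs in one place: 2-nitrophenyl in place of 2,4-dichlorophenyl on an amide-type nitrogen.

Going by the values given here, with no measured pair that isolates a change of this kind, there is nothing in the data to point to a shift in either direction. Both measured compounds sit in the same region of this assay, and the expectation is that compound 3 stays there as well, with an expected step of a 1.0-fold lower number from compound 2 to compound 3 (0.01 log units; within the scatter) that does not reach beyond the scatter. Compound 3 is therefore estimated at 50000 nM, within a range from 25000 nM to 100000 nM.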

Compound 3, half-maximal cytotoxic concentration: 63000 nM
Beside the measured number, compound 3's estimate is 1.3-fold (0.10 log units) below it, and the stated range covers the measured number.
By their numbers in this assay, from the lowest: compounds 2, 1 and 3 (each within the scatter of the next).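

In this assay, for the compounds shown here, 2-nitrophenyl in place of 2,4-dichlorophenyl on an amide-type nitrogen gives a 1.2-fold higher number from compound 2 to compound 3 (0.09 log units; within the scatter) and this is the first step in the set that isolates a single change. At this place, on a nitrogen whose other neighbour is the carbonyl carbon, the read-out cannot tell the two groups apart, even though the entering group has 2 hydrogen-bond acceptors and no chlorine, while the leaving group has 0 hydrogen-bond acceptors and 2 chlorine atoms. Nothing at hand bears on why these two results cannot be separated.

From the compounds shown here alone, all three compounds carry a substituted phenyl ring on this nitrogen and share the same core, so it remains open whether any change at this place or in the core can produce a step beyond the scatter. A carboxylic acid or an amine on that phenyl ring, or a longer alkyl chain in place of the ring, would test whether this place tolerates groups of a quite different kind in this assay.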